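This account rests on a few compounds, and the source may have more. Where it says the series, first, only, none or still open, it means among the compounds named here.

In a functional assay on NCI-H1299 cells (Homo sapiens) for antiproliferative activity, read by fluorescence and resazurin assay, with a stated time of 48 h (a higher number here means a weaker inhibitor, a lower number a stronger inhibitor), compound 1 `COc1ccc(Cn2cc(-c3ccc(O)cc3)c(-c3ccc(O)cc3)c2)cc1` gives 37300 nM while compound 2 `COc1cccc(Cn2cc(-c3ccc(O)cc3)c(-c3ccc(O)cc3)c2)c1` gives 25300 nM and compound 3 `COc1ccccc1Cn1cc(-c2ccc(O)cc2)c(-c2ccc(O)cc2)c1` gives 23100 nM on the same core. Compound 3 therefore stands within the usual scatter of both others. Compound 4 `COc1ccc(Cn2cc(-c3ccc(O)cc3)c(-c3ccc(O)cc3)c2)c(OC)c1` differs from compound 3 by methoxy in place of hydrogen on an aromatic carbon and so turns 2-methoxyphenyl into 2,4-dimethoxyphenyl. Going by the values given here, three measured steps bear on this, and each only moves the single methoxy around the ring: a 1.6-fold lower number from compound 1 to compound 3 (0.21 log units; within the scatter) and a 1.1-fold lower number from compound 2 to compound 3 (0.04 log units; within the scatter) and a 1.5-fold lower number from compound 1 to compound 2 (0.17 log units; within the scatter) all lie within the scatter. None adds a second methoxy, so this guidance is limited, and no shift beyond the scatter is expected. The expected result is a 1.1-fold higher number from compound 3 to compound 4 (0.03 log units; within the scatter) in this assay for now. Compound 4 is estimated at 25000 nM and expected to fall from 12000 nM to 50000 nM on repeated measurement.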

Compound 4, half-maximal inhibitory concentration: 31600 nM
Compound 4: middle estimate off by 1.3-fold (0.10 log units), on the low side; low and high end bracket the measured number.
By their numbers in this assay, from the lowest: compounds 3, 2, 4 and 1 (each within the scatter of the next).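

In this assay, going by these compounds alone, the earlier compounds only moved one methoxy around the ring, whereas a second methoxy now gives a 1.4-fold higher number from compound 3 to compound 4 (0.14 log units; within the scatter) and a 1.2-fold lower number from compound 1 to compound 4 (0.07 log units; within the scatter) on the same ring. Going from a 3-methoxyphenyl to the 2,4-dimethoxyphenyl group gives a 1.2-fold higher number from compound 2 to compound 4 (0.10 log units; within the scatter) as well, so this position takes a second methoxy without a shift beyond the scatter. No measurement here offers an explanation for this result. From the compounds shown here alone, whether an amine or a carboxylic acid at this position would move the number beyond the scatter remains open.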